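Chloro Replaces Methyl Ortho to the Carboxy Group

A few compounds are considered here, and "the series" means these few. Any claim that something is new, unique, unknown or untested is made for them only; others in the source may bear on it.

Compound 2 `Cc1cc(OCCCCOc2ccc(C(=O)CC(C)C)c(O)c2C)ccc1C(=O)O` gives 173 nM in an assay on HEK293 cells for positive allosteric modulation of metabotropic glutamate receptor 2 (Rattus norvegicus), read by thallium flux, with a stated time of 2.5 min; on this read-out lower numbers stand for an effect already at smaller amounts and higher numbers for an effect only at larger amounts of compound. Compound 1 `Cc1c(OCCCCOc2ccc(C(=O)O)cc2)ccc(C(=O)CC(C)C)c1O` gives 122 nM in this assay, and the step of a 1.4-fold higher number from compound 1 to compound 2 (0.15 log units; within the scatter), methyl in place of hydrogen on an aromatic carbon, leaves the two numbers inside the scatter of each other. Compound 3 `Cc1c(OCCCCOc2ccc(C(=O)O)c(Cl)c2)ccc(C(=O)CC(C)C)c1O` differs from compound 2 by chloro in place of methyl on an aromatic carbon. For the measured compounds named here, no measured step exchanges chloro for methyl, and the one step that exists stays within the scatter, so no shift beyond the scatter is expected in this assay. Compound 3 is therefore expected to give 170 nM, between 70 nM and 420 nM. That estimate amounts to a step of a 1.0-fold lower number from compound 2 to compound 3 (0.01 log units; within the scatter).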

Compound 3, half-maximal effective concentration: 151 nM
Beside the measured number, compound 3's estimate is 1.1-fold (0.05 log units) above it; low and high end bracket the measured number.
By their numbers in this assay, from the lowest: compounds 1, 3 and 2 (each within the scatter of the next).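

In this assay, chloro in place of methyl at the place ortho to a carboxy group (a 1.1-fold lower number from compound 2 to compound 3 (0.06 log units; within the scatter)) stays within the scatter, and so does chloro in place of hydrogen (a 1.2-fold higher number from compound 1 to compound 3 (0.09 log units; within the scatter)). Hydrogen, methyl and chloro at this place are thus not told apart on this read-out, and the result adds chloro as a third group to the earlier pair. No measurement given here offers an explanation for this. As far as these compounds go, whether a methoxy group, a nitrile or an amine at this place would move the number beyond the scatter stays open.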